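A few compounds are considered here, and "the series" means these few. Any claim that something is new, unique, unknown or untested is made for them only; others in the source may bear on it.

Three compounds were measured in an ADME assay on microsomes from liver (Mus musculus) for metabolic stability, read by LC-MS, with NADPH named in the record, with a stated time of 60 min, tested at 1 uM, in the absence of a further agent; a lower number here means that less of the compound is left, a higher number that more of the compound is left. Compound 1, `COc1ccc(-c2scc3c(N4CC[C@@H](NC(C)=O)C4)nc(C)nc23)cc1OC`, gives > 95%, which is a limit of the measurement rather than a number. Compound 2, `COc1ccc(-c2c(C)nc3c(N4CC[C@@H](NC(C)=O)C4)cc(C)nn23)cc1F`, also gives a limit, > 95%. Compound 3, `COc1ccc(-c2c(C)nc3c(N4CC[C@@H](NC(=O)NC(C)C)C4)cc(C)nn23)cc1OC`, likewise gives only a limit, > 95%. So compound 3 stands where every value shown stands, at the top edge of what can be read (the limit of > 95% in this assay, at which 3 of the 3 values shown sit). Compound 4, `COc1ccc(-c2c(C)nc3c(N4CC[C@@H](NS(=O)(=O)c5ccc(C(C)=O)cc5)C4)cc(C)nn23)cc1OC`, differs from compound 3 in one place: (4-acetylphenyl)sulfonyl in place of isopropylcarbamoyl on an amine nitrogen. For the measured compounds named here, no measured pair shows what such a change does here, so the expectation rests on the ceiling alone. A small downward step from compound 3 to compound 4, a number at least 10 percentage points lower from compound 3 to compound 4 (that floor lies within the scatter), is expected, most likely still within the scatter. Compound 4 is estimated at 85%, between 55% and 95%.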

Compound 4, percent of the compound remaining: > 95%
Compound 4 gave a limit, no number; the forecaster's own chance of this, stated with the estimate: 40%; middle value at least 10 percentage points away from the limit.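

For the compounds shown here, compound 3 and compound 4 both give only a limit, so no step between them can be read: the limit of > 95% in this assay, at which 4 of the 4 values shown sit. Which change to these compounds would bring the amount left down to a readable number stays open.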